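The compounds below may be only part of what the source reports. "The series", "measured", "known", "first", "only" and "open" are said of these compounds alone.

Measured in a functional assay on NCI-H460 cells (Homo sapiens) for inhibition, read by sulforhodamine B assay, with a stated time of 48 h, tested at 10 uM; a higher number here means more inhibition at the concentration tested (going by the name of the read-out), a lower number less inhibition:
compound 1 `COc1ccc(-c2cn3ccnc3c(-c3ccc4ncn(C5CCCCC5)c4c3)n2)cc1` — 91.1%
compound 2 `c1ccc2c(-c3cn4ccnc4c(-c4ccc5ncn(C6CCCCC6)c5c4)n3)cccc2c1` — 3.61%
compound 3 `Brc1ccc(-c2cn3ccnc3c(-c3ccc4ncn(C5CCCCC5)c4c3)n2)cc1` — 13.2%

Compound 3 stands second highest of the three numbers, within the scatter of compound 2 and far below compound 1. Compound 4 `FC(F)(F)c1cccc(-c2cn3ccnc3c(-c3ccc4ncn(C5CCCCC5)c4c3)n2)c1` is not yet measured; it differs from compound 3 as 3-(trifluoromethyl)phenyl in place of 4-bromophenyl on an aromatic carbon. The exchanges on the same aromatic carbon bear on this step: a number 77.9 percentage points lower from compound 1 to compound 3 (beyond the scatter) was large, while a number 9.6 percentage points higher from compound 2 to compound 3 (within the scatter) stayed within the scatter, and a number 87.5 percentage points lower from compound 1 to compound 2 (beyond the scatter) was large as well. Only compound 1 with its methoxy group reaches high inhibition; the bromo and naphthyl replacements both leave low numbers. For compound 4 the step of a number 1.8 percentage points higher from compound 3 to compound 4 (within the scatter) is expected to be none beyond the scatter. Compound 4 is therefore estimated at 15%, with a range from 0% to 45%.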

Compound 4, a percentage reported as inhibition, at one concentration (the size of the read-out at that concentration, not a potency): 4.38%
Estimate against measurement, compound 4: 10.6 percentage points above; low and high end bracket the measured number.
By their numbers in this assay, from the lowest: compounds 2, 4 and 3 (each within the scatter of the next); then compound 1.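

In this assay 3-(trifluoromethyl)phenyl joins the low compounds at this aromatic carbon: a number 8.8 percentage points lower from compound 3 to compound 4 (within the scatter) and a number 0.8 percentage points higher from compound 2 to compound 4 (within the scatter) stand against a number 86.7 percentage points lower from compound 1 to compound 4 (beyond the scatter) in this series. Of the four aryl groups, 4-methoxyphenyl alone gives high inhibition, and a third replacement of it now ends low. No measured evidence accounts for this difference.

Still open, as far as these compounds go, is whether the high inhibition depends on the methoxy group itself or on the whole 4-methoxyphenyl group. An amine or a longer ether chain in place of methoxy would bear on that.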